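Halogen swap on the aryl ketone of a chalcone-like pyrazole series

This account rests on a few compounds, and the source may have more. Where it says the series, first, only, none or still open, it means among the compounds named here.

Measured so far:
compound 1 `COc1cc(-c2cc(/C=C/C(=O)c3ccc(Cl)c(Cl)c3)[nH]n2)cc(OC)c1OC`: 6970 nM
compound 2 `COc1ccc(-c2cc(/C=C/C(=O)c3ccc(N)cc3)[nH]n2)cc1OC`: 6300 nM
compound 3 `COc1ccc(-c2cc(/C=C/C(=O)c3cc(OC)c(OC)c(OC)c3)[nH]n2)cc1OC`: 5390 nM

In a functional assay on NCI-H522 cells (Homo sapiens) for inhibition, read by sulforhodamine B assay, with a stated time of 48 h (on this read-out lower numbers stand for higher toxicity in this test and higher numbers for lower toxicity in this test), compound 1 gives the highest of the three numbers, yet its gaps to compound 2 and to compound 3 both lie within the scatter, so the three compounds cannot be ranked against each other on this read-out. Compound 4 `COc1cc(-c2cc(/C=C/C(=O)c3ccc(F)c(F)c3)[nH]n2)cc(OC)c1OC` differs from compound 1 in one place: 3,4-difluorophenyl in place of 3,4-dichlorophenyl on a carbonyl carbon. For the measured compounds named here, with no step between measured compounds to lean on, and with three rather different aryl ketones all giving values that sit within the scatter of one another, no change beyond the scatter is expected from this exchange. The expected step of a 1.0-fold higher number from compound 1 to compound 4 (0.00 log units; within the scatter) is therefore small, with no clear direction. Compound 4 is expected to give 7000 nM, within a range from 2500 nM to 20000 nM.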

Compound 4, concentration lethal to 50% of the cells: 65200 nM
The estimate for compound 4 lay 9.3-fold (0.97 log units) below the measured number; measured number above the stated range.
By their numbers in this assay, from the lowest: compounds 3, 2 and 1 (each within the scatter of the next); then compound 4.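

In this assay, 3,4-difluorophenyl in place of 3,4-dichlorophenyl on a carbonyl carbon gives a 9.4-fold higher number from compound 1 to compound 4 (0.97 log units; beyond the scatter), a step beyond the scatter. For the compounds shown here, this shows that the read-out responds to the identity of the halogen at this position, something the earlier compounds, which differ in more than one place, could not show. Nothing available here accounts for this step. From the compounds shown here alone, whether 3,4-dibromophenyl or unsubstituted phenyl at this position would stand nearer compound 1 or compound 4 remains open. So does whether the same exchange has a similar effect on the core of compound 2.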